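Selenium ring isomer of compound 2: working notes

This account rests on a few compounds, and the source may have more. Where it says the series, first, only, none or still open, it means among the compounds named here.

Measured in a functional assay on NCI-H460 cells (Homo sapiens) for cytotoxicity, read by MTT assay, with a stated time of 48 h; a higher number here means a weaker inhibitor, a lower number a stronger inhibitor:
- compound 1 `COc1ccc2[nH]c(-c3ccc[se]3)cc(=O)c2c1O`: 400 nM
- compound 2 `COc1ccc2[nH]c(-c3ccc[se]3)cc(=O)c2c1`: 2400 nM
- compound 3 `COc1ccc2[nH]c(-c3ccc(C)[se]3)cc(=O)c2c1O`: 900 nM

Compound 2 has the highest number of the three, with compound 3 nearest and compound 1 furthest. Compound 4 `COc1ccc2[nH]c(-c3cc[se]c3)cc(=O)c2c1` has the same atoms as compound 2, joined differently: a group of 5 heavy atoms (4 carbon, 1 selenium; one five-membered aromatic ring with 1 hetero atom) in place of a group of 5 heavy atoms (4 carbon, 1 selenium; one five-membered aromatic ring with 1 hetero atom), on an aromatic carbon. Within the data shown here, no measured step makes this change. The nearest guides are a 6.0-fold higher number from compound 1 to compound 2 (0.78 log units; beyond the scatter), with hydrogen in place of hydroxy, and a 2.3-fold higher number from compound 1 to compound 3 (0.35 log units; beyond the scatter), with methyl in place of hydrogen. Both are modest, so a modest step at most is expected, with neither direction favoured. The expected step in this assay is a 1.0-fold higher number from compound 2 to compound 4 (0.02 log units; within the scatter). For compound 4 the estimated value is 2500 nM, with an expected range of 900 nM to 7000 nM.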

Compound 4, half-maximal inhibitory concentration: 2300 nM
The estimate for compound 4 lay 1.1-fold (0.04 log units) above the measured number; low and high end bracket the measured number.
By their numbers in this assay, from the lowest: compound 1; then compound 3; then compounds 4 and 2 (each within the scatter of the next).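

Changing how the selenium ring is joined to the shared core gives a 1.0-fold lower number from compound 2 to compound 4 (0.02 log units; within the scatter) in this assay. Among these compounds, the two ring isomers therefore cannot be told apart at this position on the core, whereas the hydroxy and methyl changes among the earlier compounds both gave steps beyond the scatter. No evidence bears on this result.

As far as these compounds go, whether this ring change would stay as small with the hydroxy of compound 1 present remains open. Also open, from the compounds shown here alone, is how an amine or a longer chain in place of the methyl of compound 3 would read.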